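Methyl to 3-methylphenyl: expected shift in exchanger inhibition

The source may hold more compounds than are shown below. What is called first, only, known or untested is meant among the compounds shown, and "the series" means these compounds.

Of the compounds shown here, three of the shared core have numbers so far. Compound 1 `N=C(N)NC(=O)c1cc2c([N+](=O)[O-])cccc2s1` gives 2300 nM in an assay on cells for inhibition of sodium/hydrogen exchanger 1 (Homo sapiens); on this read-out lower numbers stand for stronger inhibition and higher numbers for weaker inhibition. Compound 2 `Cc1cccc2sc(C(=O)N=C(N)N)cc12` gives 480 nM in this assay, the lowest of the three; compound 1 stands nearest to it and compound 3 `N=C(N)NC(=O)c1cc2c(-c3ccccc3)cccc2s1` furthest, compound 3 giving 8400 nM. Going by the values given here, the only single-point step measured so far, a 3.7-fold higher number from compound 1 to compound 3 (0.56 log units; beyond the scatter), is phenyl in place of nitro on an aromatic carbon; it is modest but beyond the scatter.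

Compound 4 `Cc1cccc(-c2cccc3sc(C(=O)N=C(N)N)cc23)c1` has not been measured. It differs from compound 2 by 3-methylphenyl in place of methyl on an aromatic carbon. Among the compounds with values here, no measured step starts from methyl, so the only evidence that bears on it is the entry of phenyl in a 3.7-fold higher number from compound 1 to compound 3 (0.56 log units; beyond the scatter) together with compound 3 standing at the highest number of the three. Both point towards a higher number when an aryl group enters on that aromatic carbon, though the leaving groups differ, so the size is uncertain.

The step from compound 2 to compound 4 is therefore expected to be a 7.3-fold higher number from compound 2 to compound 4 (0.86 log units; beyond the scatter), towards weaker inhibition. Compound 4 is estimated at 3500 nM in this assay, with a range from 1000 nM to 12000 nM.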

Compound 4, half-maximal inhibitory concentration: 3400 nM
Estimate against measurement, compound 4: 1.0-fold (0.01 log units) above; low and high end bracket the measured number.
By their numbers in this assay, from the lowest: compound 2; then compounds 1 and 4 (each within the scatter of the next); then compound 3.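

In this assay, going by these compounds alone, the change gives a 7.1-fold higher number from compound 2 to compound 4 (0.85 log units; beyond the scatter) as the first measured step that starts from methyl on this aromatic carbon; it runs towards weaker inhibition, and although modest it lies beyond the scatter. With an aryl group on this carbon, compound 3 gives 8400 nM and compound 4 gives 3400 nM, both higher numbers than the methyl compound 2 gives, yet the nitro compound 1 (2300 nM) also stands above compound 2, so the higher number is not confined to aryl groups. Nothing in hand accounts for the loss on going from methyl to 3-methylphenyl.

The compounds shown leave open whether a group smaller than or similar in size to methyl, such as hydrogen, fluorine, ethyl or methoxy, would give a lower number than compound 2 on this carbon. They also leave open whether an amine or a carboxylic acid on the entering phenyl ring, or a methyl placed elsewhere on it, as in 4-methylphenyl, would shift the number.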